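A few compounds are considered here, and "the series" means these few. Any claim that something is new, unique, unknown or untested is made for them only; others in the source may bear on it.

Values in a toxicity assay on HEK-293T cells (Homo sapiens) for cytotoxicity, read by MTT assay, with a stated time of 48 h; on this read-out lower numbers stand for stronger inhibition and higher numbers for weaker inhibition:

- Compound 1 `C=C1[C@H](O)[C@@H](O)[C@@H](O)C(C)(C)/C=C/[C@H](C)[C@H](OC(=O)c2ccccc2)[C@@]2(O)C[C@@](C)(O)[C@H](OC(C)=O)[C@@H]2[C@H]1OCC(C)C`: > 100000 nM, a limit of the assay
- Compound 2 `C=C1[C@H](O)[C@@H](OC(=O)C(C)(C)C)[C@@H](O)C(C)(C)/C=C/[C@H](C)[C@H](OC(=O)c2ccccc2)[C@@]2(O)C[C@@](C)(O)[C@H](OC(C)=O)[C@@H]2[C@H]1OCC(C)C`: 31700 nM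

Within the data shown here, compound 2 holds the only actual number so far, at 31700 nM. Compound 3 `C=C1[C@H](O)[C@@H](OC(=O)c2cccc(C)c2)[C@@H](O)C(C)(C)/C=C/[C@H](C)[C@H](OC(=O)c2ccccc2)[C@@]2(O)C[C@@](C)(O)[C@H](OC(C)=O)[C@@H]2[C@H]1OCC(C)C` keeps the core of compound 2 and differs at one place: 3-methylphenyl in place of tert-butyl on a carbonyl carbon. Among the measured compounds shown here, one measured step bears on this, an at least 3.1-fold lower number from compound 1 to compound 2 (0.49 log units; beyond the scatter), which put (tert-butyl)carbonyl in place of hydrogen. Compound 3 keeps a carbonyl there, so the gain seen in that step is expected to persist. For the measured compounds named here, no measured step compares one such carbonyl group with another, so no direction can be favoured. The expected change is none beyond the scatter, a 1.1-fold lower number from compound 2 to compound 3 (0.02 log units; within the scatter), in this assay. The estimate for compound 3 is 30000 nM, with an expected range from 10000 nM to 90000 nM.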

Compound 3, half-maximal inhibitory concentration: 31300 nM
Compound 3: the middle estimate sits 1.0-fold (0.02 log units) below what was measured; low and high end bracket the measured number.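

In this assay, 3-methylphenyl in place of tert-butyl on the carbonyl carbon gives a 1.0-fold lower number from compound 2 to compound 3 (0.01 log units; within the scatter), so at this position a group with a six-membered aromatic ring reads the same as a branched one. (3-Methylphenyl)carbonyl in place of hydrogen on the oxygen gives an at least 3.1-fold lower number from compound 1 to compound 3 (0.50 log units; beyond the scatter), which shows that the step is not confined to (tert-butyl)carbonyl but appears with both carbonyl groups shown. The true size of that step stays undefined, as compound 1 sits at a limit and not at a number: the limit of > 100000 nM in this assay, at which 1 of the 3 values shown sits.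

With only these two carbonyl groups shown, it remains open whether one carrying an amine, a carboxylic acid or a longer chain would read differently. As far as these compounds go, it is also open whether the carbonyl is needed at all, as a simple ether on this oxygen would test.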